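Swapping 3-chlorophenyl for an aroyl group in compound 1

A few compounds are considered here, and "the series" means these few. Any claim that something is new, unique, unknown or untested is made for them only; others in the source may bear on it.

In a functional assay on SGC-7901 cells (Homo sapiens) for antiproliferative activity, read by MTT assay, with a stated time of 24 h (on this read-out lower numbers stand for stronger inhibition and higher numbers for weaker inhibition), compound 1 (`O=C(NNc1cccc(Cl)c1)c1ccccc1NS(=O)(=O)c1cnc(O)nc1O`) gives 10800 nM and compound 2 (`CCCCOc1ccc(C(=O)NNC(=O)c2cccc(NS(=O)(=O)c3cnc(O)nc3O)c2)cc1`) gives 7370 nM. Among the measured compounds shown here, these two values lie within the scatter of each other, so compound 1 stands level with the only other measured compound.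

Compound 3 (`O=C(NNC(=O)c1ccccc1NS(=O)(=O)c1cnc(O)nc1O)c1ccccc1Cl`) differs from compound 1 at a single place, an amine nitrogen: (2-chlorophenyl)carbonyl in place of 3-chlorophenyl on an amine nitrogen. There, (2-chlorophenyl)carbonyl stands in place of 3-chlorophenyl. For the measured compounds named here, no measured pair isolates this change, so the expectation rests on thin evidence. Compound 2 also carries a carbonyl on the corresponding nitrogen and gives 7370 nM, so no step beyond the scatter is expected in this assay. The estimated 1.3-fold lower number from compound 1 to compound 3 (0.10 log units; within the scatter) is therefore small. For compound 3 the expected value is 8500 nM, with an estimated range of 3500 nM to 20000 nM.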

Compound 3, half-maximal inhibitory concentration: 2410 nM
Compound 3: middle estimate off by 3.5-fold (0.55 log units), on the high side; the measured number lies below the stated range.
By their numbers in this assay, from the lowest: compound 3; then compounds 2 and 1 (each within the scatter of the next).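

In this assay, among the compounds shown here, the amine nitrogen proves to be a position where the substituent counts: (2-chlorophenyl)carbonyl in place of 3-chlorophenyl gives a 4.5-fold lower number from compound 1 to compound 3 (0.65 log units; beyond the scatter) and this is the first step that isolates a change at one place. The change brings in the carbonyl and replaces the 3-chloro pattern with the 2-chloro pattern in a single move, so the step cannot be assigned to either part. Nothing at hand accounts for the size of the step.

Open, from the compounds shown here alone, is whether the carbonyl alone carries the step, which (3-chlorophenyl)carbonyl or unsubstituted benzoyl on the same amine nitrogen would help to separate. Also open, going by these compounds, is whether the aromatic ring is needed at all, as an acetyl group at this place would test.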